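Sulfonamide in place of the pyridyl on the core

This account rests on a few compounds, and the source may have more. Where it says the series, first, only, none or still open, it means among the compounds named here.

Working notes on the series. Going by the values given here, compound 1 `Cc1n[nH]cc1-c1cccc2c1CCC2c1ncc[nH]1` is the only member with a number in a functional assay on CHO cells for agonist activity at Alpha-1D adrenergic receptor (Homo sapiens), read by FLIPR and calcium flux (on this read-out lower numbers stand for an effect already at smaller amounts and higher numbers for an effect only at larger amounts of compound), where compound 1 gives 634 nM. Compound 2 `Cn1nccc1-c1cccc2c1CCC2c1ncc[nH]1` reaches only a limit of the assay, > 10000 nM. Compound 3 `c1cncc(-c2cccc3c2CCC3c2ncc[nH]2)c1` likewise stands at a limit, > 10000 nM. The two readable steps are both large, an at least 15-fold higher number from compound 1 to compound 2 (1.19 log units; beyond the scatter) and an at least 15-fold higher number from compound 1 to compound 3 (1.19 log units; beyond the scatter). Between compound 2 and compound 3 there is a step that the two limits leave unreadable from compound 2 to compound 3 because both sit on (the limit of > 10000 nM in this assay, at which 2 of the 3 values shown sit).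

Compound 4 `CCS(=O)(=O)Nc1cccc2c1CCC2c1ncc[nH]1` carries a change of a different kind: (ethylsulfonyl)amino in place of pyridin-3-yl on an aromatic carbon. Among the compounds with values here, none of the measured steps covers such a swap; each of them exchanges one aromatic ring for another at this position, and compound 3 itself sits at the limit. The step to compound 4 will therefore only become readable if compound 4 returns a number. With nothing pointing the other way, the step of a number no higher from compound 3 to compound 4 (the limit leaves the size open) is expected to remain unreadable or small. Compound 4 is thus estimated at 10000 nM in this assay, with a range from 2000 nM to 30000 nM, and a limit is the more likely outcome.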

Compound 4, half-maximal effective concentration: > 10000 nM
Compound 4 gave a limit, no number; the forecaster's own chance of this, stated with the estimate: 65%; the middle value lies on the limit itself.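

Up to compound 3, only one aromatic ring was exchanged for another at this aromatic carbon; compound 4 shows that a group with no ring, (ethylsulfonyl)amino, also ends at a limit in this assay. The large step of an at least 15-fold higher number from compound 1 to compound 4 (1.19 log units; beyond the scatter) is the third of its kind, so among the compounds shown only 3-methyl-1H-pyrazol-4-yl gives a number at this place. The steps among compound 2, compound 3 and compound 4 cannot be read, and no order among them can be given: the limit of > 10000 nM in this assay, at which 3 of the 4 values shown sit.

From the compounds shown here alone, whether a plain amine or a carboxylic acid on this aromatic carbon would return a number stays open. So does the outcome for 1H-pyrazol-4-yl without the methyl, which would test how much of the number of compound 1 depends on that methyl.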